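Shortening the Alkoxy Chain from Allyloxy to Ethoxy

The source may report more compounds than this note shows. Statements on the series, on what has been measured and on what is new or still open speak of the compounds shown alone.

Compound 1 `CCCCCCOc1ccc2c(Cl)ccnc2c1`: > 10000 nM in a functional assay on SK-OV-3 cells (Homo sapiens) for cytotoxicity, read by MTT assay, with a stated time of 48 h (a higher number here means a weaker inhibitor, a lower number a stronger inhibitor), a limit of the assay rather than a number
Compound 2 `C=CCOc1ccc2c(NCCCN(C)C)ccnc2c1`: 4250 nM in this assay
Compound 3 `CC(C)COc1ccc2c(Cl)ccnc2c1`: 3190 nM in this assay

Compound 2 gives the highest of the two numbers in this assay; its nearest neighbour is compound 3, whose value sits within the scatter of that of compound 2. Compound 4 `CCOc1ccc2c(NCCCN(C)C)ccnc2c1` differs from compound 2 in one place: methyl in place of vinyl on a saturated chain carbon bound to an oxygen on an aromatic ring. For the measured compounds named here, the only measured step that touches the same place is the one from compound 1 to compound 3, which also shortens the group on a saturated chain carbon bound to an oxygen on an aromatic ring, and it gave an at least 3.1-fold lower number from compound 1 to compound 3 (0.49 log units; beyond the scatter). As far as these compounds go, that step starts from a limit (the limit of > 10000 nM in this assay, at which 1 of the 3 values shown sits), so its true size is unknown, and the shared core of compounds 1 and 3 differs from that of compound 2. The step from compound 2 to compound 4 is therefore expected to be small, with at most a modest move toward a lower number: a 1.4-fold lower number from compound 2 to compound 4 (0.15 log units; within the scatter). Compound 4 is estimated at 3000 nM in this assay, with a range from 1100 nM to 9000 nM.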

Compound 4, half-maximal inhibitory concentration: 6780 nM
For compound 4 the middle estimate is 2.3-fold (0.35 log units) below the measured one, and the stated range covers the measured number.
By their numbers in this assay, from the lowest: compounds 3, 2 and 4 (each within the scatter of the next, the first and the last beyond it). At a limit, above all of these: compound 1.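

In this assay the change from allyloxy to ethoxy gives a 1.6-fold higher number from compound 2 to compound 4 (0.20 log units; within the scatter) on the core shared by compound 2 and compound 4. For the compounds shown here, this is the first step at this place, on a saturated chain carbon bound to an oxygen on an aromatic ring, that runs between two real numbers on this core, with no limit at either end. It shows that losing the double bond outside aromatic rings, and going from vinyl to methyl, leaves the two values within the scatter of each other.

As far as these compounds go, whether a longer chain, a branched chain or an added amine at this place on the same core would move the number beyond the scatter remains open. Nothing shown here bears on why these two values lie so close.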